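Ethyl on the cyanoguanidine imine nitrogen of compound 1

A few compounds are considered here, and "the series" means these few. Any claim that something is new, unique, unknown or untested is made for them only; others in the source may bear on it.

Compound 1, `N#CNC(=N)NCCCCCn1nc(-c2ccccc2)ccc1=O`, gives 31% in a functional assay on the whole organism with Rattus norvegicus as the target, at a dose of 100 mg/kg; a lower number here means less inhibition, a higher number more inhibition at the dose given (going by the name of the read-out); this is the lowest of the two numbers recorded, and its nearest neighbour is compound 2, `C/N=C(\S)NCCCCn1nc(-c2ccccc2)ccc1=O`, which in this assay gives 87.1%. The step from one to the other, a number 56.1 percentage points higher from compound 1 to compound 2 (beyond the scatter), exchanges the whole cyanoguanidine terminus for a methyl-thiourea on the saturated chain carbon.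

Compound 3, `CC/N=C(/NC#N)NCCCCCn1nc(-c2ccccc2)ccc1=O`, keeps the cyanoguanidine and the chain of compound 1; the change is a group of 7 heavy atoms (4 carbon, 3 nitrogen; no ring) in place of a group of 5 heavy atoms (2 carbon, 3 nitrogen; no ring), on an amine nitrogen, that is an ethyl placed on the imine nitrogen of the terminal group.

Within the data shown here, no measured step repeats this change. Among the measured compounds shown here, the only step known, from compound 1 to compound 2, is large but replaces the entire end group together with its cyanide, so it bears on compound 3 only loosely: it shows that the cyanoguanidine end of compound 1 sits low and that an alkyl-bearing terminus can sit much higher. For compound 3 a moderate rise in this assay is therefore expected, a number 19 percentage points higher from compound 1 to compound 3 (beyond the scatter), with wide uncertainty.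

Compound 3 is expected to give about 50% in this assay, within a range of 25% to 75%.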

Compound 3, a percentage reported as inhibition, in the whole organism at one dose (the size of the read-out at that dose, not a potency): 48.2%
Compound 3: middle estimate off by 1.8 percentage points, on the high side; the range from low to high includes it.
By their numbers in this assay, from the lowest: compound 1; then compound 3; then compound 2.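

Within the cyanoguanidine series, this assay records a number 17.2 percentage points higher from compound 1 to compound 3 (beyond the scatter), a modest step for replacing the group of 5 heavy atoms with the group of 7 heavy atoms on an amine nitrogen. Unlike the step to compound 2, this one keeps the nitrile and the chain of compound 1 in place, so it isolates a single change at the end group and shows that the read-out can rise without the cyanoguanidine being given up. The count of hydrogen-bond donors falls by one in this exchange, but nothing available connects that count or the added carbons with the higher number.

The compounds shown leave open how a methyl, a propyl or a benzyl on the same nitrogen would compare with the ethyl of compound 3, and so whether the rise depends on the size of the added group or simply on substitution being present. Also open, on these data alone, is whether the ethyl-bearing cyanoguanidine would read the same on a shorter chain such as that of compound 2, since the step to compound 2 changes the end group and the chain together.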